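The compounds below may be only part of what the source reports. "The series", "measured", "known", "first", "only" and "open" are said of these compounds alone.

Measured in an in vivo ADME assay on the whole organism (plasma, strain Sprague-Dawley) for pharmacokinetics, with Rattus norvegicus as the target, read by LC-MS, at a dose of 10 mg/kg by the oral route (on this read-out higher numbers stand for higher oral bioavailability and lower numbers for lower oral bioavailability), so far:
- compound 1 `CC(C)N1CCC(Oc2ccc(C(=O)Nc3ccc(NC(=O)Nc4cc(C(C)(C)C)on4)cc3)nc2)CC1` gives 17.5%
- compound 2 `CCN1CCC(Cc2ccc(C(=O)Nc3ccc(NC(=O)Nc4cc(C(C)(C)C)on4)cc3)nc2)CC1` gives 12%
- compound 3 `CC(C)(C)c1cc(NC(=O)Nc2ccc(NC(=O)c3ccc(OC4CCN(C(C)(C)C)CC4)cn3)cc2)no1` gives 22%

Compound 1 stands second highest of these three numbers; its nearest neighbour is compound 3 and its furthest is compound 2, and both gaps lie within the usual scatter of the measurement. The unmeasured compound 4 `CC(C)(C)c1cc(NC(=O)Nc2ccc(NC(=O)c3ccc(OC4CCNCC4)cn3)cc2)no1` differs from compound 1 in one place: hydrogen in place of isopropyl on an amine nitrogen in a ring. All three measured steps also change only what sits on that amine nitrogen in the six-membered non-aromatic ring with 1 nitrogen, and none of them moved the read-out beyond the scatter: a number 5.5 percentage points lower from compound 1 to compound 2 (within the scatter), a number 4.5 percentage points higher from compound 1 to compound 3 (within the scatter), and a number 10 percentage points higher from compound 2 to compound 3 (within the scatter). The change to compound 4 goes further than any of these, removing the alkyl group altogether rather than swapping one for another, so the measured steps only partly cover it. Still, on this evidence the expected step is none beyond the scatter, estimated as a number 2.5 percentage points lower from compound 1 to compound 4 (within the scatter). The estimate for compound 4 is 15%, with a range from 5% to 30%.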

Compound 4, oral bioavailability: 1%
Estimate against measurement, compound 4: 14 percentage points above; the measured number lies below the stated range.
By their numbers in this assay, from the lowest: compound 4; then compounds 2, 1 and 3 (each within the scatter of the next).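

In this assay, the amine nitrogen in the ring turns out to be a sensitive position: exchanging one alkyl group for another there stayed within the scatter, but replacing the group with hydrogen brings a number 16.5 percentage points lower from compound 1 to compound 4 (beyond the scatter) and a number 21 percentage points lower from compound 3 to compound 4 (beyond the scatter). The listed step from the ethyl-bearing compound points the same way, a number 11 percentage points lower from compound 2 to compound 4 (beyond the scatter), although that step also changes how the ring is attached, so among these compounds only the one with hydrogen on the nitrogen stands clearly apart. Nothing given here explains why the number falls.

Going by these compounds, whether a methyl group on that nitrogen would be enough to keep the higher numbers remains open. So does the outcome with an acetyl group there, which would put a carbonyl on the nitrogen in place of a simple alkyl chain.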